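This account rests on a few compounds, and the source may have more. Where it says the series, first, only, none or still open, it means among the compounds named here.

Measured so far:
- Compound 1 `C=CS(=O)(=O)NC/C=C/c1cc(OC)cc(O)c1C(=O)OC(C)C`: 72.3%
- Compound 2 `C=CS(=O)(=O)NC/C=C/c1cc(OC)cc(O)c1C(=O)OCC1CCCCC1`: 56.4%

These values come from a functional assay on MV4-11 cells (Homo sapiens) for inhibition, read by luminescence, with a stated time of 72 h, tested at 5 uM; a higher number here means more inhibition of growth at the concentration tested, a lower number less inhibition of growth. Of the two measured compounds, compound 2 stands lowest at 56.4%, while compound 1 reaches 72.3%.

The next compound is compound 3 `C=CS(=O)(=O)NC/C=C/c1cc(OC)cc(O)c1C(=O)OCc1ccc(Br)cc1`, which differs from compound 2 in one place: 4-bromophenyl in place of cyclohexyl on a saturated chain carbon bound to an oxygen next to a carbonyl group. In words, 4-bromophenyl replaces cyclohexyl on a saturated chain carbon bound to an oxygen next to a carbonyl group.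

Within the data shown here, only one measured step bears on this change, a number 15.9 percentage points lower from compound 1 to compound 2 (beyond the scatter). It is modest and was made on the same oxygen, but neither measured compound carries a six-membered aromatic ring there, so it gives no clear direction. The expected change in this assay is therefore none beyond the scatter, with an estimated a number 1.4 percentage points lower from compound 2 to compound 3 (within the scatter). For compound 3 the estimated value is 55%, with an expected range from 35% to 74%.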

Compound 3, percent growth inhibition at one concentration: 61%
Compound 3: middle estimate off by 6 percentage points, on the low side, within the range that was stated.
By their numbers in this assay, from the lowest: compounds 2 and 3 (each within the scatter of the next); then compound 1.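

In this assay, 4-bromophenyl in place of cyclohexyl on this saturated chain carbon gives a number 4.6 percentage points higher from compound 2 to compound 3 (within the scatter) here, so the data do not separate the aromatic ring carrying bromine from the non-aromatic carbon ring at this place. The second step, a number 11.3 percentage points lower from compound 1 to compound 3 (beyond the scatter) in this comparison, shows that 4-bromobenzyl, like cyclohexylmethyl before it, falls short of isopropyl on this oxygen, and the pattern now holds for both of these groups with no compound shown against it. No measured evidence accounts for these numbers.

The compounds shown leave open how an unsubstituted benzyl or a 4-fluorobenzyl group would read on this oxygen, so the part played by the bromine remains unknown. On these data alone, how an ethyl group or a free carboxylic acid would compare with compound 1 also remains open.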